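Replacing 3-methylphenyl with 2-hydroxyphenyl on the ring nitrogen

The compounds below may be only part of what the source reports. "The series", "measured", "known", "first", "only" and "open" are said of these compounds alone.

Compound 1 `CC(C)c1ccc(-c2nc(SCc3cn(CC(=O)NC(=O)Nc4ccccn4)nn3)nc(Nc3ccc(Cl)cc3)c2C#N)cc1`: > 64000 nM (a limit of the assay)
Compound 2 `CC(C)c1ccc(-c2nc(SCc3cn(CC(=O)NC(=O)Nc4ccccn4)nn3)nc(Nc3ccccc3F)c2C#N)cc1`: > 64000 nM (a limit of the assay)
Compound 3 `Cc1cccc(Nc2nc(SCc3cn(CC(=O)NC(=O)Nc4ccccn4)nn3)nc(-c3ccc(C(C)C)cc3)c2C#N)c1`: 25300 nM

Among the measured compounds shown here, in a functional assay on MGC-803 cells (Homo sapiens) for inhibition, read by MTT assay, with a stated time of 72 h (on this read-out higher numbers stand for weaker inhibition and lower numbers for stronger inhibition), compound 3 gives the only plain number; the other two values are limits, namely (the limit of > 64000 nM in this assay, at which 2 of the 3 values shown sit). Compound 4 `CC(C)c1ccc(-c2nc(SCc3cn(CC(=O)NC(=O)Nc4ccccn4)nn3)nc(Nc3ccccc3O)c2C#N)cc1` differs from compound 3 by 2-hydroxyphenyl in place of 3-methylphenyl on a nitrogen on an aromatic ring. For the measured compounds named here, two measured steps touch the same nitrogen: an at least 2.5-fold lower number from compound 1 to compound 3 (0.40 log units; beyond the scatter) and an at least 2.5-fold lower number from compound 2 to compound 3 (0.40 log units; beyond the scatter), each starting from a limit, so neither shows how a 2-hydroxyphenyl behaves there. With no closer guide, a step within the usual scatter is expected, a 1.1-fold higher number from compound 3 to compound 4 (0.04 log units; within the scatter). Compound 4 is therefore estimated at 28000 nM, between 9000 nM and 90000 nM.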

Compound 4, half-maximal inhibitory concentration: 16400 nM
The estimate for compound 4 lay 1.7-fold (0.23 log units) above the measured number; measured number inside the range.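

Compound 4 shows that a 2-hydroxyphenyl, with its hydrogen-bond donor and acceptor, can take the place of 3-methylphenyl on this nitrogen and still give a plain number: a 1.5-fold lower number from compound 3 to compound 4 (0.19 log units; within the scatter). Hydroxy in place of fluoro gives an at least 3.9-fold lower number from compound 2 to compound 4 (0.59 log units; beyond the scatter), and 2-hydroxyphenyl in place of 4-chlorophenyl gives an at least 3.9-fold lower number from compound 1 to compound 4 (0.59 log units; beyond the scatter), but the true size of both steps stays unknown. Compound 1 and compound 2 each stand at a limit, not a number: the limit of > 64000 nM in this assay, at which 2 of the 4 values shown sit.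

Going by these compounds, a phenyl ring carrying an amine or a carboxylic acid on this nitrogen remains open. So does whether such a group would move the number beyond the scatter.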